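The source may hold more compounds than are shown below. What is called first, only, known or untested is meant among the compounds shown, and "the series" means these compounds.

Measured compounds:
compound 1 `CC(=O)O[C@@H]1[C@@H](OC(C)=O)[C@@H](O)[C@@H](CO)O[C@H]1NC(=S)NNC(=O)Cn1cnc2c(N)ncnc21` — > 100000 nM
compound 2 `CC(=O)O[C@@H]1[C@@H](OC(C)=O)[C@@H](O)CO[C@H]1NC(=S)NNC(=O)Cn1cnc2c(N)ncnc21` — > 200000 nM
compound 3 `CC(=O)O[C@@H]1[C@@H](OC(C)=O)[C@@H](O)[C@@H](CO)O[C@H]1NC(=S)NNC(=O)Cn1cnc2ccccc21` — > 100000 nM

In a functional assay on PG cells (Homo sapiens) for cytotoxicity, read by MTT assay, with a stated time of 48 h (on this read-out lower numbers stand for an effect already at smaller amounts and higher numbers for an effect only at larger amounts of compound), compound 1 gives > 100000 nM, which is a limit of the assay. Compound 2 gives > 200000 nM, also a limit. Compound 3 gives > 100000 nM, again a limit. The change hydrogen in place of hydroxymethyl on a saturated ring carbon therefore yields a step that the two limits leave unreadable from compound 1 to compound 2. The two cores differ as a group of 9 heavy atoms (7 carbon, 2 nitrogen; one five-membered aromatic ring with 2 hetero atoms, one six-membered aromatic ring of carbon only) in place of a group of 10 heavy atoms (5 carbon, 5 nitrogen; one five-membered aromatic ring with 2 hetero atoms, one six-membered aromatic ring with 2 hetero atoms), on a saturated chain carbon bound to a carbonyl carbon, and that step is a step that the two limits leave unreadable from compound 1 to compound 3. Compound 4 `CC(=O)O[C@@H]1[C@@H](OC(C)=O)[C@@H](O)CO[C@H]1NC(=S)NNC(=O)Cn1cnc2ccccc21` carries the same change from compound 3, namely (hydrogen in place of hydroxymethyl on a saturated ring carbon); its place matches that of the earlier change word for word. In this assay compound 4 is expected to stay at a limit as well, an expected step that the limit leaves unreadable from compound 3 to compound 4, because compound 1 and compound 2 both sit at limits in a step that the two limits leave unreadable from compound 1 to compound 2 and compound 3 sits at > 100000 nM. The estimate for compound 4 is 200000 nM, expected between 100000 nM and 500000 nM.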

Compound 4, half-maximal effective concentration: > 200000 nM
Compound 4: no number, only a limit (the forecaster's own chance of this, stated with the estimate: 90%); the middle value sits exactly at the limit.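

In this assay compound 4 gives > 200000 nM, which is a limit, so no step can be read from compound 3 or compound 2 to compound 4. The compounds shown leave open whether either change alters cytotoxicity at all.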